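Replacing the furan on the chalcone carbonyl with an aminopyrimidine

The source may report more compounds than this note shows. Statements on the series, on what has been measured and on what is new or still open speak of the compounds shown alone.

Of the compounds shown here, three sharing one core have been measured in a functional assay on A549 cells (Homo sapiens) for antiproliferative activity, read by XTT assay, with a stated time of 72 h; a higher number here means a weaker inhibitor, a lower number a stronger inhibitor. Compound 1 `COc1ccc(-c2cc3ccccc3nc2/C=C/C(=O)c2ccccc2)cc1` gives 7410 nM. Compound 2 `COc1ccc(-c2cc3ccccc3nc2/C=C/C(=O)c2ccc(N)cc2)cc1` gives 7530 nM. Compound 3 `COc1ccc(-c2cc3ccccc3nc2/C=C/C(=O)c2ccco2)cc1` gives 6130 nM, the lowest of the three numbers, although its gap to either neighbour stays inside the scatter: a 1.2-fold lower number from compound 1 to compound 3 (0.08 log units; within the scatter) and a 1.2-fold lower number from compound 2 to compound 3 (0.09 log units; within the scatter) are both small, as is a 1.0-fold higher number from compound 1 to compound 2 (0.01 log units; within the scatter).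

Compound 4 `COc1ccc(-c2cc3ccccc3nc2/C=C/C(=O)c2cnc(N)nc2C)cc1` has not yet been measured. It differs from compound 3 in one place: 2-amino-4-methylpyrimidin-5-yl in place of furan-2-yl on a carbonyl carbon. The two steps that touch this same carbonyl carbon, from phenyl and from 4-aminophenyl to furan-2-yl, each moved the number by an amount within the scatter, so the group on this carbon has so far made little difference across three quite different aromatic rings. Within the data shown here, no step exists for an aminopyrimidine here, so the expectation rests on those two steps alone.

On that basis compound 4 is expected to give about 6500 nM, with a range from 2500 nM to 17000 nM. The expected step, a 1.1-fold higher number from compound 3 to compound 4 (0.03 log units; within the scatter), is estimated to be no larger than the scatter, in no clear direction.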

Compound 4, half-maximal inhibitory concentration: > 10000 nM
Compound 4 ended at the assay's limit; the forecaster's own chance of this, stated with the estimate: 10%; at least 1.5-fold (0.18 log units) between middle value and limit.
By their numbers in this assay, from the lowest: compounds 3, 1 and 2 (each within the scatter of the next). At a limit, above all of these: compound 4.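

Compound 4 is the only one of the four that sits at a limit of this assay, so its entry is a limit and not a number: the limit of > 10000 nM in this assay, at which 1 of the 4 values shown sits.

Only floors can be read from it: an at least 1.6-fold higher number from compound 3 to compound 4 (0.21 log units; that floor lies within the scatter), an at least 1.3-fold higher number from compound 2 to compound 4 (0.12 log units; that floor lies within the scatter) and an at least 1.3-fold higher number from compound 1 to compound 4 (0.13 log units; that floor lies within the scatter). Each floor lies within the scatter, so the change from furan-2-yl to 2-amino-4-methylpyrimidin-5-yl on this carbonyl carbon is not shown to exceed the scatter, though it is not shown to stay inside it either. Among these compounds, what is new is that phenyl, 4-aminophenyl and furan-2-yl on this carbon all gave measured values within the scatter of one another, whereas this six-membered ring with 2 hetero atoms is the first group here to give no measured value at all.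

The compounds shown leave open how far the value of compound 4 lies past the limit, and which part of the new group matters. A pyrimidin-5-yl ring carrying only the amine or only the methyl would separate those two substituents from the ring itself.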